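Working notes on three measured anilides and one analogue

The source may report more compounds than this note shows. Statements on the series, on what has been measured and on what is new or still open speak of the compounds shown alone.

Measured in an assay on isolated protein for inhibition of high affinity 3',5'-cyclic-AMP phosphodiesterase 7A (Homo sapiens), read by cAMP accumulation, with a stated time of 10 min; a higher number here means a weaker inhibitor, a lower number a stronger inhibitor:
Compound 1 `COc1nc2c(c(=O)n(C)c(=O)n2C)n1CC(=O)Nc1ccc(C(C)(C)C)cc1` gives > 200000 nM, a limit of the assay.
Compound 2 `CCOc1nc2c(c(=O)n(C)c(=O)n2C)n1CC(=O)Nc1ccc(C(C)(C)C)cc1` gives > 200000 nM, also a limit of the assay.
Among the measured compounds shown here, compound 3 `CCOc1nc2c(c(=O)n(C)c(=O)n2C)n1CCCC(=O)Nc1ccc(C(C)(C)C)cc1` gives 54300 nM, the only number among the three.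

From compound 2 to compound 1 the change is hydrogen in place of methyl on a saturated chain carbon bound to an oxygen on an aromatic ring; the step that the two limits leave unreadable from compound 2 to compound 1 cannot be read because of the limit of > 200000 nM in this assay, at which 2 of the 3 values shown sit. The difference between the cores of compound 2 and compound 3 is not broken down here. Compound 4 `CCOc1nc2c(c(=O)n(C)c(=O)n2C)n1CCCC(=O)Nc1ccc(C(C)C)cc1` is not yet measured; it differs from compound 3 by hydrogen in place of methyl on a saturated chain carbon bound to an aromatic carbon and two saturated chain carbons. This is the same kind of change as from compound 2 to compound 1, but not the same: there the place is on a saturated chain carbon bound to an oxygen on an aromatic ring, here on a saturated chain carbon bound to an aromatic carbon and two saturated chain carbons. The earlier step has no readable size, so the expectation rests on compound 3 alone with 54300 nM. For compound 4 the step is expected to be a 1.5-fold higher number from compound 3 to compound 4 (0.17 log units; within the scatter), within the usual scatter. The estimate for compound 4 is 80000 nM, between 30000 nM and 200000 nM.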

Compound 4, half-maximal inhibitory concentration: 96300 nM
The estimate for compound 4 lay 1.2-fold (0.08 log units) below the measured number, and the stated range covers the measured number.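

In this assay, tert-butyl to isopropyl gives a 1.8-fold higher number from compound 3 to compound 4 (0.25 log units; within the scatter), so on this one core the two groups are not told apart. Among the compounds shown here, the only other step of this kind, hydrogen in place of methyl at a different place on the core shared by compound 1 and compound 2, cannot be read because both compounds are at a limit of the assay: the limit of > 200000 nM in this assay, at which 2 of the 4 values shown sit. No readable pair therefore exists on a second core, and the result shows neither that the change carries over from one core to another nor that it fails to.

On these data alone, what an amine or a carboxylic acid in place of tert-butyl would give remains open. So does the effect of a longer chain than the one in compound 3.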